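A few compounds are considered here, and "the series" means these few. Any claim that something is new, unique, unknown or untested is made for them only; others in the source may bear on it.

Working notes on the sulfonylurea series. In a functional assay on HEK293 cells for antagonist activity at thromboxane A2 receptor (Homo sapiens), read by fluorescence and calcium flux (on this read-out lower numbers stand for stronger inhibition and higher numbers for weaker inhibition), compound 1 `Cc1cccc(Oc2ccc(C#N)cc2S(=O)(=O)NC(=O)NC(C)C)c1` gives 2380 nM. Compound 2 `Cc1cccc(Oc2ccc(C#N)cc2S(=O)(=O)NC(=O)NC(C)(C)C)c1` carries methyl in place of hydrogen on a saturated chain carbon bound to an amide-type nitrogen and two saturated chain carbons and gives 1050 nM in this assay, which is a 2.3-fold lower number from compound 1 to compound 2 (0.36 log units; beyond the scatter). Compound 3 `CC(C)NC(=O)NS(=O)(=O)c1cc(C#N)ccc1Oc1ccc(Cl)cc1` gives 9460 nM in this assay, which is a 4.0-fold higher number from compound 1 to compound 3 (0.60 log units; beyond the scatter); of the three measured compounds, compound 3 has the highest number. Compound 4 `CC(C)(C)NC(=O)NS(=O)(=O)c1cc(C#N)ccc1Oc1ccc(Cl)cc1` is not yet measured. Compound 4 differs from compound 3 by methyl in place of hydrogen on a saturated chain carbon bound to an amide-type nitrogen and two saturated chain carbons, the same change made from compound 1 to compound 2, at the same place. The two cores differ by 4-chlorophenyl in place of 3-methylphenyl on an oxygen on an aromatic ring. For compound 4 in this assay the step is expected to be a 2.4-fold lower number from compound 3 to compound 4 (0.37 log units; beyond the scatter), resting on the step of compound 2, a 2.3-fold lower number from compound 1 to compound 2 (0.36 log units; beyond the scatter). Compound 4 is thus estimated at 4000 nM in this assay, with a range from 1800 nM to 9000 nM.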

Compound 4, half-maximal inhibitory concentration: 5640 nM
Compound 4: the middle estimate sits 1.4-fold (0.15 log units) below what was measured; the range from low to high includes it.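

In this assay, the change from isopropyl to tert-butyl gives a 1.7-fold lower number from compound 3 to compound 4 (0.22 log units; within the scatter), and its size agrees with that of the same change on the other core: the same change on two cores in this assay, a 2.3-fold lower number (0.36 log units; beyond the scatter) from compound 1 to compound 2 and a 1.7-fold lower number (0.22 log units; within the scatter) from compound 3 to compound 4, 1.4-fold (0.13 log units) apart, within the scatter of two such steps. The change to 4-chlorophenyl in place of 3-methylphenyl gives a 5.4-fold higher number from compound 2 to compound 4 (0.73 log units; beyond the scatter), and it also holds between the isopropyl and tert-butyl compounds: the same change on two cores in this assay, a 4.0-fold higher number (0.60 log units; beyond the scatter) from compound 1 to compound 3 and a 5.4-fold higher number (0.73 log units; beyond the scatter) from compound 2 to compound 4, 1.4-fold (0.13 log units) apart, within the scatter of two such steps. Both changes therefore carry over within these four compounds, but this rests on a single pair of cores, and the isopropyl to tert-butyl step on the core of compound 3 cannot be told from the scatter, so no general rule for the series follows.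

Going by these compounds, it remains open whether a longer chain or a cyclohexyl group in place of tert-butyl would carry over in the same way. On these data alone, it is also open whether either step would hold with a carboxylic acid in place of the nitrile.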